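A Pyridyl for a Tolyl: Cytotoxicity Expectation

The source may report more compounds than this note shows. Statements on the series, on what has been measured and on what is new or still open speak of the compounds shown alone.

Compound 1 `Cc1ccc(-c2ccc(C3(C)CC(S(=O)(=O)c4ccc(F)cc4)=C(c4ccc(/C(N)=N\O)cc4)O3)cc2)cc1` is one of two compounds examined in an ADME assay on J774.A1 cells (Mus musculus) for cytotoxicity, read by MTT assay, with a stated time of 72 h (a lower number here means that less compound is tolerated, a higher number that more compound is tolerated), where compound 1 gives 7910 nM, the lower of the two numbers. Compound 2 `CC1(Cc2ccccc2)CC(S(=O)(=O)c2c(F)cccc2F)=C(c2ccc(/C(N)=N\O)cc2)O1` gives 27000 nM in this assay, a higher number; the gap between them is beyond the scatter, so compound 2 is the better tolerated of the pair. Compound 3 `CC1(c2ccc(-c3ccncc3)cc2)CC(S(=O)(=O)c2ccc(F)cc2)=C(c2ccc(/C(N)=N\O)cc2)O1` has not yet been measured. It differs from compound 1 by pyridin-4-yl in place of 4-methylphenyl on an aromatic carbon. Among the compounds with values here, no pair of measured compounds shows a step of this kind, so the direction is open; a step of a 1.3-fold higher number from compound 1 to compound 3 (0.10 log units; within the scatter) is expected, not beyond the scatter. Compound 3 is thus estimated at 10000 nM, within 4000 nM to 25000 nM.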

Compound 3, half-maximal cytotoxic concentration: 6750 nM
The estimate for compound 3 lay 1.5-fold (0.17 log units) above the measured number; measured number inside the range.
By their numbers in this assay, from the lowest: compounds 3 and 1 (each within the scatter of the next); then compound 2.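

Within the data shown here, the step of a 1.2-fold lower number from compound 1 to compound 3 (0.07 log units; within the scatter) in this assay is the first reading at this position, on an aromatic carbon para to a large group. It shows that pyridin-4-yl, with its ring nitrogen and one hydrogen-bond acceptor, can replace 4-methylphenyl here without moving the number beyond the scatter. Nothing measured here offers an explanation for this outcome.

From the compounds shown here alone, whether an amine or a carboxylic acid at this place would leave the number equally undisturbed remains open. So does whether the same exchange would behave alike on a different core.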